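The source may hold more compounds than are shown below. What is called first, only, known or untested is meant among the compounds shown, and "the series" means these compounds.

In a functional assay on the whole organism (artery, strain albino) with Rattus norvegicus as the target, with a stated time of 240 min, at a dose of 10 mg/kg by the oral route (a higher number here means more inhibition at the dose given (going by the name of the read-out), a lower number less inhibition), the measured compounds stand as follows:

compound 1, `CC1=C(C(=O)Nc2ccc(F)cc2)C(c2ccc([N+](=O)[O-])cc2)N=C(SCc2ccccc2)N1`: 32.3%
compound 2, `CC1=C(C(=O)Nc2ccc(F)cc2)C(c2ccc([N+](=O)[O-])cc2)N=C(SCc2ccc(Cl)cc2)N1`: 33.3%
compound 3, `CC1=C(C(=O)Nc2ccc([N+](=O)[O-])cc2)C(c2cccc([N+](=O)[O-])c2)N=C(SCc2ccccc2)N1`: 21%

Compound 1 and compound 2 share a core and differ in a single place: chloro in place of hydrogen on an aromatic carbon. The step this change makes in this assay is a number 1 percentage points higher from compound 1 to compound 2 (within the scatter). Compound 3 differs from compound 1 in more than one place; the difference between the two cores is not broken down here. What the values show is that compound 3 gives the lowest number of the three, and that its gap to compound 1 and its gap to compound 2 both lie beyond the usual scatter.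

Compound 4, `CC1=C(C(=O)Nc2ccc([N+](=O)[O-])cc2)C(c2cccc([N+](=O)[O-])c2)N=C(SCc2ccccc2Cl)N1`, has not yet been measured in this assay. Going by the values given here, it is made from compound 3 by a change of the same kind as the one from compound 1 to compound 2: chloro in place of hydrogen on an aromatic carbon. The two changes are not the same, though: in compound 4 the chloro sits ortho to a large group, whereas in compound 2 it sits para to a large group.

The expectation for compound 4 rests on compound 3 with 21% as the starting point and on the step from compound 1 to compound 2, a number 1 percentage points higher from compound 1 to compound 2 (within the scatter), which lay within the scatter. On that basis the estimated step from compound 3 to compound 4 is a number 1 percentage points higher from compound 3 to compound 4 (within the scatter). Since the place of the chloro differs from the measured case, the range for this expectation is kept wide. Compound 4 is thus expected to give about 22% in this assay, estimated to fall between 10% and 35%.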

Compound 4, a percentage reported as inhibition, in the whole organism at one dose (the size of the read-out at that dose, not a potency): 12.8%
Compound 4: the middle estimate sits 9.2 percentage points above what was measured; the measured number falls inside the stated range.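

In this assay, chloro in place of hydrogen on the core of compound 3 gives a number 8.2 percentage points lower from compound 3 to compound 4 (within the scatter), and set beside the same kind of change on the core of compound 1, it gives no sign that the two cores respond differently: the same change on two cores in this assay, a number 1 percentage points higher (within the scatter) from compound 1 to compound 2 and a number 8.2 percentage points lower (within the scatter) from compound 3 to compound 4, 9.2 percentage points apart, within the scatter of two such steps
As far as these two pairs go, the change can be carried from one core to the other without a step beyond the scatter on either. Going by these compounds alone, this does not show that the change is without effect or that it transfers exactly, since there are only two pairs, read at a single dose, and the chloro sits ortho to a large group in compound 4 but at a different place in compound 2, so that core and place cannot be told apart.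

Still open, on these data alone, is whether chloro at one and the same place on both cores gives matching steps, and whether a methoxy group or a carboxylic acid on the benzyl ring, or a longer chain in place of benzyl on the sulfur, would give a step beyond the scatter. Also open is which of the several differences between the cores of compound 1 and compound 3 goes with the gap between them, as no pair shown changes one of these alone.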